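The source may report more compounds than this note shows. Statements on the series, on what has been measured and on what is new or still open speak of the compounds shown alone.

Measured so far:
compound 1 `CCNC(=O)Nc1nc2cc(-c3cnc(N4CCC(C(=O)O)CC4)nc3)cc(-c3ccccn3)c2s1`: > 800 ug/mL
compound 2 `CCNC(=O)Nc1nc2cc(-c3ccc(N4CCC(C)(C(=O)O)CC4)nc3)cc(-c3ccccn3)c2s1`: > 800 ug/mL
compound 3 `CCNC(=O)Nc1nc2cc(-c3cncc(N4CCC(C)(C(=O)O)CC4)c3)cc(-c3ccccn3)c2s1`: > 800 ug/mL

In a physicochemical assay for solubility, read by turbidimetry, in phosphate buffer, with a stated time of 24 h, at pH 7.4 (a higher number here means a more soluble compound, a lower number a less soluble compound), compound 1 gives > 800 ug/mL, which is a limit of the assay rather than a number. Compound 2 also sits at a limit with > 800 ug/mL. Compound 3 likewise reaches a limit at > 800 ug/mL. Within the data shown here, all three therefore stand at the limit of > 800 ug/mL in this assay, at which 3 of the 3 values shown sit, so no step between them can be sized, and compound 1 cannot be placed above or below the others.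

Compound 4 `CCNC(=O)Nc1nc2cc(-c3cnc(N4CCCC4(C)C(=O)O)nc3)cc(-c3ccccn3)c2s1` has not yet been measured in this assay. Compared with compound 1, the change is 2-carboxy-2-methylpyrrolidin-1-yl in place of 4-carboxypiperidin-1-yl on an aromatic carbon. The carboxylic acid is kept, and the three measured compounds all reach the limit, so the expected step from compound 1 to compound 4 is none beyond the scatter, as a number no higher from compound 1 to compound 4 (the limit leaves the size open) states. Compound 4 is expected to give about 800 ug/mL, within a range from 400 ug/mL to 1600 ug/mL.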

Compound 4, solubility: > 800 ug/mL
Compound 4: only a limit was reported (the forecaster's own chance of this, stated with the estimate: 80%); the middle value sits exactly at the limit.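

No step can be read from compound 1 to compound 4, because both values are limits of the assay and not numbers: the limit of > 800 ug/mL in this assay, at which 4 of the 4 values shown sit.

How much the solubilities of these compounds truly differ, if at all, stays open.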